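The compounds below may be only part of what the source reports. "The series", "measured", "known", "first", "only" and "open" are said of these compounds alone.

Of the compounds shown here, two have been measured so far in a functional assay, with a stated time of 30 min, tested at 50 uM; on this read-out lower numbers stand for a weaker effect and higher numbers for a stronger effect at the one concentration tested. Compound 1 `Cc1c(C)c2c(c(C)c1O)CCC(C)(C(=O)NCCS)O2` gives 61%. Compound 2 `CCOC(=O)C(CS)NC(=O)/C=C/c1cc(C(C)(C)C)c(O)c(C(C)(C)C)c1` gives 37%, the lower of the two numbers, and its gap to compound 1 lies beyond the usual scatter. Compound 3 `CC(C)(C)c1cc(/C=C/C(=O)NCCS)cc(C(C)(C)C)c1O` has not yet been measured. It differs from compound 2 in one place: hydrogen in place of ethoxycarbonyl on a saturated chain carbon bound to an amide-type nitrogen and a saturated chain carbon. Compound 3 is expected to gain moderately, by a number 13 percentage points higher from compound 2 to compound 3 (beyond the scatter), since it carries the same 2-sulfanylethyl group that compound 1 carries with 61%. Compound 3 is therefore estimated at 50%, within a range from 30% to 70%.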

Compound 3, a percentage reported as activity, at one concentration (the size of the read-out at that concentration, not a potency): 34%
For compound 3 the middle estimate is 16 percentage points above the measured one, within the range that was stated.
By their numbers in this assay, from the lowest: compounds 3 and 2 (each within the scatter of the next); then compound 1.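

In this assay, hydrogen in place of ethoxycarbonyl on a saturated chain carbon bound to an amide-type nitrogen and a saturated chain carbon gives a number 3 percentage points lower from compound 2 to compound 3 (within the scatter). On this read-out, the ethoxycarbonyl group can therefore be present or absent at this position without a difference that can be told from the scatter. Nothing further shown here explains this result.

Only ethoxycarbonyl and hydrogen are shown at this position, so it remains open whether a carboxylic acid or an amine there would give a different read-out.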